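This account rests on a few compounds, and the source may have more. Where it says the series, first, only, none or still open, it means among the compounds named here.

Of the compounds shown here, three have been measured and a fourth has not. Compound 1 `COc1cc(Br)cc(/C=C/C(=O)c2ccccc2)c1O` is tested in a functional assay on MCF7 cells (Homo sapiens) for antiproliferative activity, read by sulforhodamine B assay, with a stated time of 72 h, tested at 30 uM (a higher number here means a weaker effect of the compound at the concentration tested, a lower number a stronger effect), where compound 1 gives 28.1%. Compound 3 `COc1cc(Br)cc(/C=C/C(=O)c2ccc(C)cc2)c1O` differs from compound 1 by methyl in place of hydrogen on an aromatic carbon; in this assay compound 3 gives 61.5%, and that change made a number 33.4 percentage points higher from compound 1 to compound 3 (beyond the scatter). Compound 2 `O=C(/C=C/c1cc(F)cc(F)c1O)c1ccccc1` differs from compound 1 in more than one place; the difference between the two cores is not broken down here. In this assay compound 2 gives 37.6%, which lies within the scatter of the value of compound 1. Compound 4 `Cc1ccc(C(=O)/C=C/c2cc(F)cc(F)c2O)cc1` is not yet measured; it differs from compound 2 by methyl in place of hydrogen on an aromatic carbon, and the place of entry is described in the same words as for the change from compound 1 to compound 3, so it is the same change, occurring twice among these compounds. For the measured compounds named here, because the only measured instance of it is a number 33.4 percentage points higher from compound 1 to compound 3 (beyond the scatter), a step of similar size toward a weaker effect is expected for compound 4, namely a number 30.4 percentage points higher from compound 2 to compound 4 (beyond the scatter). As this rests on a single pair, the range is kept wide. Compound 4 is therefore estimated to give 68% in this assay, expected to fall between 45% and 90%.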

Compound 4, a percentage reported as activity, at one concentration (the size of the read-out at that concentration, not a potency): 35.3%
For compound 4 the middle estimate is 32.7 percentage points above the measured one; measured number below the stated range.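

In this assay, methyl in place of hydrogen on an aromatic carbon did not carry over from one core to the other, and the two instances of this change differ: the same change on two cores in this assay, a number 33.4 percentage points higher (beyond the scatter) from compound 1 to compound 3 and a number 2.3 percentage points lower (within the scatter) from compound 2 to compound 4, 35.7 percentage points apart, beyond the scatter of two such steps. On the core of compound 2 the change gives a number 2.3 percentage points lower from compound 2 to compound 4 (within the scatter), so the large step seen on the core of compound 1 cannot be assumed for a second core in this series. This shows that the result of the change depends on the core across these two pairs, but it does not show which feature of the cores is responsible, nor how a third core would behave, and the two cores differ in more than one place.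

Going by these compounds, it remains open whether the bromine and methoxy of compound 1 or the two fluorines of compound 2 set the size of the step. On these data alone, it also remains open how each core would respond to an ethyl chain, a methoxy group or an amine in the place of the methyl.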